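The source may hold more compounds than are shown below. What is called first, only, known or untested is meant among the compounds shown, and "the series" means these compounds.

Measured so far in a functional assay on PC-3 cells (Homo sapiens) for cytotoxicity, read by MTT assay; a higher number here means a weaker inhibitor, a lower number a stronger inhibitor:
- Compound 1 `COc1ccc2cc([C@H](C)c3nnc(SCc4c(C)cc(C)cc4C)n3-c3cccc(Cl)c3)ccc2c1`: 16300 nM
- Compound 2 `COc1ccc(CSc2nnc([C@@H](C)c3ccc4cc(OC)ccc4c3)n2-c2ccc(Cl)cc2)cc1`: <= 400000 nM
- Compound 3 `COc1ccc2cc([C@H](C)c3nnc(SCc4ccc(C)cc4)n3-c3ccc(F)cc3)ccc2c1`: 229000 nM

Compound 2 has no exact number, and its <= 400000 nM is a limit. Compound 4 `COc1ccc2cc([C@H](C)c3nnc(SCc4ccc(Cl)cc4)n3-c3ccc(Cl)cc3)ccc2c1` differs from it in one place, with chloro in place of methoxy on an aromatic carbon, turning 4-methoxybenzyl into 4-chlorobenzyl: chloro in place of methoxy on an aromatic carbon.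

For the measured compounds named here, no measured pair shows this change alone, so the only guide is the spread between compound 1 at 16300 nM and compound 3 at 229000 nM. A moderate move toward stronger inhibition in this assay is expected, though with wide uncertainty. The estimated change is a step that the limit leaves unreadable from compound 2 to compound 4. For compound 4 the expected half-maximal inhibitory concentration is 80000 nM, with an estimated range of 15000 nM to 350000 nM.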

Compound 4, half-maximal inhibitory concentration: 5800 nM
Compound 4: middle estimate off by 14-fold (1.14 log units), on the high side; measured number outside the range, below it.
By their numbers in this assay, from the lowest: compound 4; then compound 1; then compound 3.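

The step from compound 2 to compound 4 cannot be read, because compound 2 carries only a limit and not a number: the limit of <= 400000 nM in this assay, at which 1 of the 4 values shown sits.

The compounds shown leave open how far chloro in place of methoxy, on its own, shifts the value in this assay.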